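Aryl substituent variation on the tetrazolyl acetamide series

The source may report more compounds than this note shows. Statements on the series, on what has been measured and on what is new or still open speak of the compounds shown alone.

Measured compounds:
compound 1 `Cc1cc(NC(=O)Cn2nnc(-c3cccc(Cl)c3)n2)n(C2CCCCC2)n1`, 300 nM
compound 2 `Cc1cc(NC(=O)Cn2nnc(-c3ccccc3F)n2)n(C2CCCCC2)n1`, 187 nM
compound 3 `Cc1ccc(-c2nnn(CC(=O)Nc3cc(C)nn3C3CCCCC3)n2)cc1`, 111 nM

All three share one core and differ only in the aryl group on the tetrazole. In an assay on HEK293 cells for activation of Kir3.1/Kir3.2 (Homo sapiens), read by thallium flux (on this read-out lower numbers stand for an effect already at smaller amounts and higher numbers for an effect only at larger amounts of compound), compound 3 gives the lowest number of the three. The step of a 2.7-fold lower number from compound 1 to compound 3 (0.43 log units; beyond the scatter) is the only one beyond the scatter; the steps of a 1.6-fold lower number from compound 1 to compound 2 (0.21 log units; within the scatter) and a 1.7-fold lower number from compound 2 to compound 3 (0.23 log units; within the scatter) are both within it, so compound 3 and compound 2 cannot be ordered against each other.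

Compound 4 `COc1ccc(-c2nnn(CC(=O)Nc3cc(C)nn3C3CCCCC3)n2)cc1` is not yet measured. It differs from compound 3 by methoxy in place of methyl on an aromatic carbon. Among the measured compounds shown here, no measured pair tests this exact change; the measured steps bear on it only in showing that swapping one aryl substituent for another moved this assay by at most a modest amount, and among the single-substituent steps only a 2.7-fold lower number from compound 1 to compound 3 (0.43 log units; beyond the scatter) went beyond the scatter. On that basis a step of no more than the scatter is expected in either direction, giving an estimated step of a 1.2-fold higher number from compound 3 to compound 4 (0.07 log units; within the scatter). Compound 4 is therefore expected to give about 130 nM, with a range from 50 nM to 350 nM.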

Compound 4, half-maximal effective concentration: 175 nM
Estimate against measurement, compound 4: 1.3-fold (0.13 log units) below; low and high end bracket the measured number.
By their numbers in this assay, from the lowest: compounds 3, 4, 2 and 1 (each within the scatter of the next, the first and the last beyond it).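

In this assay, among the compounds shown here, methoxy in place of methyl on the aromatic carbon para to a large group brings in one more heavy atom, an oxygen, and a hydrogen-bond acceptor, and the result is a 1.6-fold higher number from compound 3 to compound 4 (0.20 log units; within the scatter); at this position, this change therefore produces no step that can be told from the scatter. The 4-methoxyphenyl group also cannot be separated from the other two aryl groups, with a 1.1-fold lower number from compound 2 to compound 4 (0.03 log units; within the scatter) and a 1.7-fold lower number from compound 1 to compound 4 (0.23 log units; within the scatter), so the 3-chlorophenyl group, which lies beyond the scatter from the 4-methylphenyl group, does not lie beyond it from the 4-methoxyphenyl group. No supporting data bear on this result, and it stands here without an explanation.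

As far as these compounds go, whether a longer chain such as ethoxy, an amine such as dimethylamino or a carboxylic acid at the same place would also stay within the scatter of methyl and methoxy remains open. From the compounds shown here alone, the shared core is constant across all four compounds, so whether the sizes of these steps carry over to another core also remains open.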